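The source may report more compounds than this note shows. Statements on the series, on what has been measured and on what is new or still open speak of the compounds shown alone.

Measured compounds in a functional assay on KM12 cells (Homo sapiens) for inhibition, read by sulforhodamine B assay, with a stated time of 48 h, tested at 10 uM; a higher number here means more inhibition at the concentration tested (going by the name of the read-out), a lower number less inhibition:

- compound 1, `COc1ccc(-c2cn3ccnc3c(-c3ccc4ncn(C5CCCCC5)c4c3)n2)cc1`: 83.2%
- compound 2, `c1cn2cc(-c3ccsc3)nc(-c3ccc4ncn(C5CCCCC5)c4c3)c2n1`: 15.4%
- compound 3, `Clc1ccc(-c2cn3ccnc3c(-c3ccc4ncn(C5CCCCC5)c4c3)n2)cc1`: 10.6%

Compound 1 stands highest of the three numbers in this assay; compound 2 is the nearest to it and compound 3 the furthest, both steps beyond the scatter. The shared core is kept throughout, and the variation sits on one aromatic carbon. Replacing the 4-methoxyphenyl by thiophen-3-yl gives a number 67.8 percentage points lower from compound 1 to compound 2 (beyond the scatter); replacing methoxy by chloro gives a number 72.6 percentage points lower from compound 1 to compound 3 (beyond the scatter). Between compound 2 and compound 3 the step is a number 4.8 percentage points lower from compound 2 to compound 3 (within the scatter).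

Compound 4, `COc1ccccc1-c1cn2ccnc2c(-c2ccc3ncn(C4CCCCC4)c3c2)n1`, differs from compound 1 as follows: 2-methoxyphenyl in place of 4-methoxyphenyl on an aromatic carbon. Within the data shown here, no measured step moves the methoxy from one place to another on the phenyl; the two measured steps from compound 1 both remove the methoxyphenyl entirely and are large downward. Compound 4 keeps the methoxy, so a loss as large as those is not the default expectation, but some loss is plausible. Compound 4 is estimated at 45%, range 10% to 85%, a step of a number 38.2 percentage points lower from compound 1 to compound 4 (beyond the scatter), with wide uncertainty.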

Compound 4, a percentage reported as inhibition, at one concentration (the size of the read-out at that concentration, not a potency): 3.58%
Estimate against measurement, compound 4: 41.4 percentage points above; measured number outside the range, below it.
By their numbers in this assay, from the lowest: compounds 4, 3 and 2 (each within the scatter of the next, the first and the last beyond it); then compound 1.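

In this assay keeping the methoxy is not enough: with the same atoms joined differently, 2-methoxyphenyl in place of 4-methoxyphenyl gives a number 79.6 percentage points lower from compound 1 to compound 4 (beyond the scatter), so at this position on the shared core the outcome depends on where the methoxy sits on the phenyl, not only on which group is present. Against the other replacements, the change gives a number 7 percentage points lower from compound 3 to compound 4 (within the scatter) and a number 11.8 percentage points lower from compound 2 to compound 4 (beyond the scatter), which leaves compound 1 as the only high number of the four. No measurement at hand accounts for the loss on moving the methoxy.

From the compounds shown here alone, it remains open whether an ethoxy group or an amine in place of the methoxy of compound 1 would hold the number. These single-concentration readings also leave the potency of compound 1 undefined.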